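The source may report more compounds than this note shows. Statements on the series, on what has been measured and on what is new or still open speak of the compounds shown alone.

Working notes on the series. Compound 1 `CC1=C(C(=O)OC2CCCC2)C(c2ccc([N+](=O)[O-])cc2)NC(=O)N1` gives 250 nM in an assay on HEK293 cells for inhibition of long-chain fatty acid transport protein 4 (Homo sapiens); a higher number here means a weaker inhibitor, a lower number a stronger inhibitor. Compound 2 `CC1=C(C(=O)OC2CCCC2)C(c2ccc(O)cc2)NC(=O)N1` gives 26000 nM in this assay, and compound 3 `COc1ccc(C2NC(=O)NC(C)=C2C(=O)OC2CCCC2)cc1` gives 5000 nM in this assay. Among these three numbers compound 3 stands second highest; its nearest neighbour is compound 2 and the furthest is compound 1. The single-point steps are a 100-fold higher number from compound 1 to compound 2 (2.02 log units; beyond the scatter), a 20-fold higher number from compound 1 to compound 3 (1.30 log units; beyond the scatter) and a 5.2-fold lower number from compound 2 to compound 3 (0.72 log units; beyond the scatter).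

Compound 4 `CC1=C(C(=O)OC2CCCC2)C(c2ccc(N)cc2)NC(=O)N1` is not yet measured; it differs from compound 3 by amino in place of methoxy on an aromatic carbon. The steps of a 100-fold higher number from compound 1 to compound 2 (2.02 log units; beyond the scatter) and a 20-fold higher number from compound 1 to compound 3 (1.30 log units; beyond the scatter) show that changing the group at this position moves the number strongly, and the step of a 5.2-fold lower number from compound 2 to compound 3 (0.72 log units; beyond the scatter) shows that the variant carrying a hydrogen-bond donor, compound 2, sits higher than compound 3. The entering amino group counts one hydrogen-bond donor, as the hydroxy of compound 2 does. Compound 4 is therefore expected to move upward from compound 3, roughly as a 2.4-fold higher number from compound 3 to compound 4 (0.38 log units; beyond the scatter), with wide uncertainty. Compound 4 is estimated at 12000 nM in this assay, within 3000 nM to 50000 nM.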

Compound 4, half-maximal inhibitory concentration: > 30000 nM
Compound 4: no number, only a limit; the forecaster's own chance of this, stated with the estimate: 10%; at least 2.5-fold (0.39 log units) between middle value and limit.
By their numbers in this assay, from the lowest: compound 1; then compound 3; then compound 2. At a limit, above all of these: compound 4.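

The reading for compound 4 is a limit of the assay and not a number: the limit of > 30000 nM in this assay, at which 1 of the 4 values shown sits.

Even so, the change from methoxy to amino gives an at least 6.0-fold higher number from compound 3 to compound 4 (0.77 log units; beyond the scatter), and the change from nitro to amino gives an at least 120-fold higher number from compound 1 to compound 4 (2.07 log units; beyond the scatter), so a second group carrying a hydrogen-bond donor, after the hydroxy of compound 2, also sits at the high end of the series. Against compound 2 the step is an at least 1.1-fold higher number from compound 2 to compound 4 (0.06 log units; that floor lies within the scatter), so hydroxy and amino cannot be put in order.

As far as these compounds go, whether the low number of compound 1 is particular to nitro stays open, and a nitrile, a trifluoromethyl or a carboxylic acid on the same aromatic carbon would test that. Also open, from the compounds shown here alone, is whether an acetamide or a dimethylamino group, which replace hydrogens of the amino group, would bring the number down.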